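This account rests on a few compounds, and the source may have more. Where it says the series, first, only, none or still open, it means among the compounds named here.

Measured compounds:
Compound 1, `CCN(Cc1ccc(Br)cc1)c1ccc(C(=O)N2CCc3ccc(OS(N)(=O)=O)cc3C2)cc1`: 78.2%
Compound 2, `NS(=O)(=O)Oc1ccc2c(c1)CN(C(=O)c1cccc(N3CCN(Cc4ccccc4)CC3)c1)CC2`: 0%
Compound 3, `CN(CCCN1CCCCC1)c1cccc(C(=O)N2CCc3ccc(OS(N)(=O)=O)cc3C2)c1`: 24.1%

All three numbers come from an assay on HEK293 cells for inhibition of Steryl-sulfatase (Homo sapiens), tested at 0.1 uM; a higher number here means a stronger effect of the compound at the concentration tested, a lower number a weaker effect. Within this set compound 3 stands second of three. Its nearest neighbour is compound 2, whose number in this assay is lower than that of compound 3 by a margin beyond the scatter, so compound 3 is read as the stronger of the two. Its furthest neighbour is compound 1, whose number in this assay lies above that of compound 3 by a larger margin, again beyond the scatter, so compound 1 is the strongest of the three.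

The next compound, compound 4, `CCCN(CCC)c1cccc(C(=O)N2CCc3ccc(OS(N)(=O)=O)cc3C2)c1`, has not yet been measured. It differs from compound 3 in one place: dipropylamino in place of methyl(3-(piperidin-1-yl)propyl)amino on an aromatic carbon

For the measured compounds named here, no pair of measured compounds differs in only one place, so there is no measured step to lean on. Going by the values given here, the expectation for this assay is a rise beyond the scatter, estimated as a number 20.9 percentage points higher from compound 3 to compound 4 (beyond the scatter), because compound 1, the one compound without a ring on its amino group, gives 78.2%. The number for compound 4 in this assay is estimated at 45%, in the range from 15% to 75%.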

Compound 4, a percentage reported as inhibition, at one concentration (the size of the read-out at that concentration, not a potency): 8.3%
Compound 4: middle estimate off by 36.7 percentage points, on the high side, outside the stated range (below it).
By their numbers in this assay, from the lowest: compounds 2 and 4 (each within the scatter of the next); then compound 3; then compound 1.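

In this assay, for the compounds shown here, dipropylamino in place of methyl(3-(piperidin-1-yl)propyl)amino on an aromatic carbon, meta to a large group, gives a number 15.8 percentage points lower from compound 3 to compound 4 (beyond the scatter) and is the only step that can be read at a single place. At this position, then, replacing the larger group carrying the piperidine ring with a smaller open-chain amino group does not raise the read-out, and the group carrying the ring is the better of the two. No measurement is available to explain this step, and it cannot separate the loss of the ring from the loss of the ring nitrogen or the change in the chains on the amino group.

Still open, from the compounds shown here alone, is which part of the departing group supports the higher read-out: a morpholine ring in place of the piperidine ring, or a shorter chain leading to the piperidine ring, would help to separate these parts. A carboxylic acid at the end of a propyl chain would show how far this position accepts a different end group.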